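Ester-Bearing Amine Analogue of a Chalcone Series

This account rests on a few compounds, and the source may have more. Where it says the series, first, only, none or still open, it means among the compounds named here.

Compound 1 `CCN(CC)Cc1c(OC)cc(OC)c(C(=O)/C=C/c2ccccc2Cl)c1O`: 4200 nM
Compound 2 `COc1cc(OC)c(C(=O)/C=C/c2ccccc2Cl)c(O)c1CN(C)C`: 400 nM

In a functional assay on PC-3 cells (Homo sapiens) for antiproliferative activity, with a stated time of 72 h (on this read-out higher numbers stand for weaker inhibition and lower numbers for stronger inhibition), compound 2 gives the lowest of the two numbers, and the nearest value is that of compound 1. Going by the values given here, the only step that changes groups on the amine nitrogen is an 11-fold lower number from compound 1 to compound 2 (1.02 log units; beyond the scatter). Compound 3 `COC(=O)CN(C)Cc1c(OC)cc(OC)c(C(=O)/C=C/c2ccccc2Cl)c1O` carries methoxycarbonyl in place of hydrogen on a saturated chain carbon bound to an amine nitrogen. Since the one comparable alteration at this amine moved the number well beyond the scatter, this step is estimated to shift it in the other direction, toward a higher number, by a 3.8-fold higher number from compound 2 to compound 3 (0.57 log units; beyond the scatter). Compound 3 is therefore expected to give about 1500 nM, within 400 nM to 6000 nM.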

Compound 3, half-maximal inhibitory concentration: 7200 nM
Beside the measured number, compound 3's estimate is 4.8-fold (0.68 log units) below it; the whole stated range lies below it.
By their numbers in this assay, from the lowest: compound 2; then compounds 1 and 3 (each within the scatter of the next).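

In this assay, an 18-fold higher number from compound 2 to compound 3 (1.26 log units; beyond the scatter) shows that methoxycarbonyl on a saturated chain carbon bound to an amine nitrogen removes the advantage held by the dimethylamino compound. With a 1.7-fold higher number from compound 1 to compound 3 (0.23 log units; within the scatter) as the remaining comparison, the diethylamino and ((methoxycarbonyl)methyl)(methyl)amino compounds cannot be told apart, so only compound 2 stands clear of the others. Nothing measured here accounts for this shift. Going by these compounds, whether a carboxylic acid in place of the methyl ester, or a longer chain carrying the ester, would give a number nearer that of compound 2 stays open.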